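The compounds below may be only part of what the source reports. "The series", "measured", "known", "first", "only" and "open" are said of these compounds alone.

Three esters share one chain and differ only in the group on the oxygen next to the carbonyl. Compound 1 `COC(C)(C)CCCC(C)C/C=C/C(C)=C/C(=O)OC(C)(C)C` gives 6.36 in a physicochemical assay for lipophilicity; on this read-out higher numbers stand for higher lipophilicity and lower numbers for lower lipophilicity. Compound 2 `COC(C)(C)CCCC(C)C/C=C/C(C)=C/C(=O)OC1CC1` gives 5.71, and compound 3 `COC(C)(C)CCCC(C)C/C=C/C(C)=C/C(=O)OC1CCCC1` gives 7.01. Compound 3 therefore stands highest of the three: the step is a number 0.65 log units higher from compound 1 to compound 3 (beyond the scatter), and the larger step is a number 1.30 log units higher from compound 2 to compound 3 (beyond the scatter); the remaining pair shows a number 0.65 log units lower from compound 1 to compound 2 (beyond the scatter).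

Compound 4 `CCN(CC)C(=O)/C=C(C)/C=C/CC(C)CCCC(C)(C)OC` changes a different kind of thing: diethylamino in place of cyclopentyloxy on a carbonyl carbon. None of the three measured steps alters the atom bound to the carbonyl carbon; each only swaps one ring or branched group for another on that same oxygen, and those swaps moved this assay by modest to large amounts. So the measured steps set the scale of what a change at this end of the molecule can do, but they do not show the direction of replacing an oxygen-linked ring with a nitrogen bearing two ethyl groups. The expectation is a step lower, a number 1.71 log units lower from compound 3 to compound 4 (beyond the scatter), with wide uncertainty. Compound 4 is accordingly estimated at 5.3, within a range from 4.5 to 6.1.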

Compound 4, partition coefficient: 4.82
The estimate for compound 4 lay 0.48 log units above the measured number; the measured number falls inside the stated range.
By their numbers in this assay, from the lowest: compound 4; then compound 2; then compound 1; then compound 3.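

Every earlier change at this position kept an oxygen on the carbonyl carbon and only swapped the group carried by that oxygen, whereas compound 4 replaces the oxygen-linked group with diethylamino, giving a diethylcarbamoyl group instead of an ester. In this assay, this new kind of change gives a lower number against all three esters, whichever group the ester carries: against the cyclopentyl ester (a number 2.19 log units lower from compound 3 to compound 4 (beyond the scatter)), against the tert-butyl ester (a number 1.54 log units lower from compound 1 to compound 4 (beyond the scatter)), and against the cyclopropyl ester (a number 0.89 log units lower from compound 2 to compound 4 (beyond the scatter)), so compound 4 falls under even compound 2, the lowest of the esters. The data shown offer no measurement that explains this drop.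

Among the compounds shown here, with diethylamino as the only nitrogen group on the carbonyl carbon, these compounds cannot separate the effect of exchanging oxygen for nitrogen from the effect of the two ethyl groups. Compounds with dimethylamino, a pyrrolidine ring attached through its nitrogen, or a free carboxylic acid at the same carbon would show whether the lower number holds beyond this single group.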